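Swapping the aryl group on the hydrazone arm

The compounds below may be only part of what the source reports. "The series", "measured", "known", "first", "only" and "open" are said of these compounds alone.

Three compounds sharing one core have been examined in a functional assay on MCF7 cells (Homo sapiens) for cytotoxicity, read by MTT assay, with a stated time of 48 h; on this read-out lower numbers stand for stronger inhibition and higher numbers for weaker inhibition. Compound 1 `O=C(CSc1nnc(-c2ccncc2)o1)N/N=C/c1ccc(F)cc1` gives 13500 nM. Compound 2 `O=C(CSc1nnc(-c2ccncc2)o1)N/N=C/c1ccccc1F` gives 21800 nM, and compound 3 `O=C(CSc1nnc(-c2ccncc2)o1)N/N=C/c1cc(Br)cc(Br)c1O` gives 9010 nM. Compound 3 stands at the lowest number of the three: there is a 1.5-fold lower number from compound 1 to compound 3 (0.18 log units; within the scatter) and a 2.4-fold lower number from compound 2 to compound 3 (0.38 log units; beyond the scatter), while between the other two there is a 1.6-fold higher number from compound 1 to compound 2 (0.21 log units; within the scatter).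

Compound 4 `COc1cc(/C=N/NC(=O)CSc2nnc(-c3ccncc3)o2)ccc1O` carries 4-hydroxy-3-methoxyphenyl in place of 3,5-dibromo-2-hydroxyphenyl on a carbon with a double bond to nitrogen. The measured steps that bear on this change are the three exchanges of the aryl group on the same carbon, of which two stayed within the scatter and one was modest. On that basis no step beyond the scatter is expected in this assay from compound 3 to compound 4, in either direction, and the expected step is a 1.3-fold higher number from compound 3 to compound 4 (0.12 log units; within the scatter). Compound 4 is therefore estimated to give 12000 nM, with a range from 5000 nM to 30000 nM.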

Compound 4, half-maximal inhibitory concentration: 3780 nM
For compound 4 the middle estimate is 3.2-fold (0.50 log units) above the measured one, and the stated range ends above it.
By their numbers in this assay, from the lowest: compound 4; then compounds 3, 1 and 2 (each within the scatter of the next, the first and the last beyond it).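

In this assay, the 4-hydroxy-3-methoxyphenyl group on the carbon with a double bond to nitrogen separates compound 4 from all three earlier aryl groups, with a 2.4-fold lower number from compound 3 to compound 4 (0.38 log units; beyond the scatter), a 3.6-fold lower number from compound 1 to compound 4 (0.55 log units; beyond the scatter) and a 5.8-fold lower number from compound 2 to compound 4 (0.76 log units; beyond the scatter). For the compounds shown here, this shows that the position allows a wider span than the earlier compounds revealed, and that the lowest number of the four comes from a group without the fluorine or bromine carried by the others. Nothing measured here accounts for this result.

Going by these compounds, it remains open whether the hydroxy or the methoxy group alone would hold the lower number. On these data alone, it is also open how an amine or a carboxylic acid on the aryl ring at this position would compare.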